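A few compounds are considered here, and "the series" means these few. Any claim that something is new, unique, unknown or untested is made for them only; others in the source may bear on it.

Measured compounds in an assay on Prostate gland for inhibition of steroid 5-alpha-reductase (Rattus norvegicus); on this read-out higher numbers stand for weaker inhibition and lower numbers for stronger inhibition:
compound 1, `CCCCC(c1ccccc1)n1ccc2cc(/C(C)=C/C(=O)Nc3ccccc3OCCCC(=O)O)ccc21`, 9.8 nM
compound 2, `CCCCCC(c1ccccc1)n1ccc2cc(/C(C)=C/C(=O)Nc3ccccc3OCCCC(=O)O)ccc21`, 25 nM
compound 3, `C/C(=C\C(=O)Nc1ccccc1OCCCC(=O)O)c1ccc2c(ccn2C(c2ccccc2)c2ccc(C(F)(F)F)cc2)c1`, 8.1 nM

Compound 3 gives the lowest number of the three, though its gap to compound 1 lies within the scatter, while the step of a 3.1-fold lower number from compound 2 to compound 3 (0.49 log units; beyond the scatter) is beyond it. The earlier steps shown here change the same position: a 2.6-fold higher number from compound 1 to compound 2 (0.41 log units; beyond the scatter) and a 1.2-fold lower number from compound 1 to compound 3 (0.08 log units; within the scatter), the latter within the scatter. Compound 4 is `C/C(=C\C(=O)Nc1ccccc1OCCCC(=O)O)c1ccc2c(ccn2C(c2ccccc2)c2ccccn2)c1`. It differs from compound 3 in one place: pyridin-2-yl in place of 4-(trifluoromethyl)phenyl on a saturated chain carbon bound to an aromatic carbon and an aromatic nitrogen. Among the measured compounds shown here, no measured step swaps one aromatic ring for another at this carbon; the steps that bear on it show only that butyl, pentyl and 4-(trifluoromethyl)phenyl are all tolerated there, with modest differences between them. A small step in either direction is therefore expected for compound 4, most likely a somewhat higher number, a 1.9-fold higher number from compound 3 to compound 4 (0.27 log units; within the scatter). The estimate for compound 4 in this assay is 15 nM, with a range from 5 nM to 50 nM.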

Compound 4, half-maximal inhibitory concentration: 37 nM
The estimate for compound 4 lay 2.5-fold (0.39 log units) below the measured number; measured number inside the range.
By their numbers in this assay, from the lowest: compounds 3 and 1 (each within the scatter of the next); then compounds 2 and 4 (each within the scatter of the next).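

In this assay, this step swaps one aromatic ring for another on the saturated chain carbon bound to an aromatic carbon and an aromatic nitrogen, and it shows that the two rings are not interchangeable there: pyridin-2-yl in place of 4-(trifluoromethyl)phenyl gives a 4.6-fold higher number from compound 3 to compound 4 (0.66 log units; beyond the scatter). Pyridin-2-yl in place of butyl gives a 3.8-fold higher number from compound 1 to compound 4 (0.58 log units; beyond the scatter), while pyridin-2-yl in place of pentyl gives only a 1.5-fold higher number from compound 2 to compound 4 (0.17 log units; within the scatter), so an aromatic ring at this carbon does not by itself match the butyl compound. No evidence is available to explain this difference between the two rings.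

Going by these compounds, whether the step follows from the ring nitrogen or from the loss of the trifluoromethyl group stays open. Also open, on these data alone, is how a plain phenyl or a pyridin-4-yl would read at this carbon.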